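The source may hold more compounds than are shown below. What is called first, only, known or untested is meant among the compounds shown, and "the series" means these compounds.

Measured compounds:
compound 1 `O=c1cc(-c2ccc(O)c(O)c2)oc2cc(OCCO)ccc12` with 16400 nM
compound 2 `C[N+](C)(C)CCCOc1c(-c2ccc(O)c(O)c2)oc2ccccc2c1=O` with 1200 nM
compound 3 `C[N+](C)(C)CCCOc1c(-c2ccc(O)c(O)c2)oc2cc(O)ccc2c1=O` with 3800 nM

In a functional assay for inhibition, with Rattus norvegicus as the target, using microsomes (on this read-out higher numbers stand for weaker inhibition and lower numbers for stronger inhibition), compound 1 gives 16400 nM, the highest of the three numbers. Compound 2 gives 1200 nM and compound 3 gives 3800 nM. The two cores, that of compound 1 and that of compound 2, differ in more than one place, and the difference between them is not broken down here.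

One change is seen twice. Between compound 2 and compound 3 it is hydroxy in place of hydrogen on an aromatic carbon, and it made a 3.2-fold higher number from compound 2 to compound 3 (0.50 log units; beyond the scatter). The unmeasured compound 4 `O=c1c(O)c(-c2ccc(O)c(O)c2)oc2cc(OCCO)ccc12` carries the same kind of change relative to compound 1: hydroxy in place of hydrogen on an aromatic carbon. The place is not the same, however. In compound 3 the hydroxy sits on a six-membered aromatic ring of carbon only, meta to a fused ring and para to a fused ring. In compound 4 it sits on a six-membered aromatic ring with one oxygen, ortho to a 3,4-dihydroxyphenyl group and ortho to a group of one heavy atom, two atoms from the ring oxygen. So the surroundings of the new group differ, and the earlier step is only a rough guide.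

Among the compounds with values here, for compound 4 the expected step is a 1.4-fold lower number from compound 1 to compound 4 (0.14 log units; within the scatter), a smaller move than the earlier one, because the only precedent, a 3.2-fold higher number from compound 2 to compound 3 (0.50 log units; beyond the scatter), was made at a different place and rests on a single pair. The estimate for compound 4 in this assay is 12000 nM, with a range from 4000 nM to 35000 nM.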

Compound 4, half-maximal inhibitory concentration: 13800 nM
The estimate for compound 4 lay 1.2-fold (0.06 log units) below the measured number; the range from low to high includes it.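

In this assay, hydroxy in place of hydrogen on the core of compound 1 gives a 1.2-fold lower number from compound 1 to compound 4 (0.07 log units; within the scatter), so at this place the new group leaves the number indistinguishable from that of the parent compound. Set beside the earlier case, the same kind of change does not give the same result on the two cores, so a step read on one core cannot simply be carried over to the other: the same change on two cores in this assay, a 3.2-fold higher number (0.50 log units; beyond the scatter) from compound 2 to compound 3 and a 1.2-fold lower number (0.07 log units; within the scatter) from compound 1 to compound 4, 3.8-fold (0.58 log units) apart, beyond the scatter of two such steps. This does not show what lies behind the gap, since each step rests on a single pair, the two cores differ in more than one place, and the hydroxy of compound 3 sits on a ring of carbon only, while that of compound 4 sits on a six-membered aromatic ring with one oxygen, two atoms from the ring oxygen.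

Still open, as far as these compounds go, is whether hydroxy entering at one and the same place on both cores would give matching steps, which would help separate the effect of place from that of core. Also open, from the compounds shown here alone, is how a methoxy group or an amine would read in this assay on the carbon that carries the hydroxy in compound 4.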